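A few compounds are considered here, and "the series" means these few. Any claim that something is new, unique, unknown or untested is made for them only; others in the source may bear on it.

Measured compounds in an ADME assay on A549 cells (Homo sapiens) for cytotoxicity, read by MTT assay, with a stated time of 48 h; a higher number here means a weaker inhibitor of growth, a lower number a stronger inhibitor of growth:
Compound 1 `O=C(/C=C\c1ccc(O)cc1)N1N=C(c2ccncc2)OC1c1c[nH]c2ccccc12` gives only the assay limit, > 30 ug/mL.
Compound 2 `COc1ccc(/C=C\C(=O)N2N=C(c3ccncc3)OC2c2c[nH]c3ccccc23)cc1` gives only the assay limit, > 30 ug/mL.
Compound 3 `O=C(/C=C\c1cccc(Cl)c1Cl)N1N=C(c2ccncc2)OC1c1c[nH]c2ccccc12` gives only the assay limit, > 30 ug/mL.

Compound 3 thus stands at the limit, not at a number, and the same holds for both other measured compounds (the limit of > 30 ug/mL in this assay, at which 3 of the 3 values shown sit). The steps a step that the two limits leave unreadable from compound 1 to compound 2, a step that the two limits leave unreadable from compound 1 to compound 3 and a step that the two limits leave unreadable from compound 2 to compound 3 are all unreadable; none shows whether any change in the aryl group on the double-bonded chain carbon moves the read-out at all.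

Compound 4 `O=C(/C=C\c1cccc(Br)c1)N1N=C(c2ccncc2)OC1c1c[nH]c2ccccc12` is not yet measured. The change from compound 3 is 3-bromophenyl in place of 2,3-dichlorophenyl on a double-bonded chain carbon bound to a double-bonded chain carbon. The measured steps that bear on it are a step that the two limits leave unreadable from compound 1 to compound 3 and a step that the two limits leave unreadable from compound 2 to compound 3, which also swap the aryl group on the double-bonded chain carbon, but both are unreadable, so no size or direction can be taken from them. The expected step is a step that the limit leaves unreadable from compound 3 to compound 4, no movement beyond the scatter. Compound 4 is estimated at 40 ug/mL in this assay, within 20 ug/mL to 100 ug/mL, and most likely will again be reported only as a limit.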

Compound 4, concentration for 50% growth inhibition: > 30 ug/mL
Compound 4: only a limit was reported (the forecaster's own chance of this, stated with the estimate: 80%); the middle value lies beyond the limit too.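

Compound 4 gives no readable step from compound 1, compound 2 or compound 3 in this assay, as all four compounds stand at the same limit: the limit of > 30 ug/mL in this assay, at which 4 of the 4 values shown sit. The compounds shown leave open whether any aryl group on the double-bonded chain carbon moves the growth-inhibition read-out at all.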